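From Methoxycarbonyl to Ethoxycarbonyl: Tolerance in HeLa Cells

The source may hold more compounds than are shown below. What is called first, only, known or untested is meant among the compounds shown, and "the series" means these compounds.

Measured so far:
Compound 1 `CCOC(=O)c1sc2cc(Oc3ccnc(C(=O)NC)c3)ccc2c1C`: > 100000 nM (a limit of the assay)
Compound 2 `CNC(=O)c1cc(Oc2ccc3c(C)c(C(=O)OC)sc3c2)ccn1`: 15700 nM
Compound 3 `CNC(=O)c1cc(Oc2ccc3ccc(C(=O)OC)cc3c2)ccn1`: 33800 nM

In an ADME assay on HeLa cells (Homo sapiens) for cytotoxicity, read by MTT assay, with a stated time of 2 days (a lower number here means that less compound is tolerated, a higher number that more compound is tolerated), compound 2 gives 15700 nM and compound 3 gives 33800 nM. For compound 1 the value > 100000 nM is a limit, not a number. The step of an at least 6.3-fold higher number from compound 2 to compound 1 (0.80 log units; beyond the scatter) is therefore only a lower bound, because of the limit of > 100000 nM in this assay, at which 1 of the 3 values shown sits. The change behind it is methyl in place of hydrogen on a saturated chain carbon bound to an oxygen next to a carbonyl group.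

Compound 4 `CCOC(=O)c1ccc2ccc(Oc3ccnc(C(=O)NC)c3)cc2c1` is not yet measured. It differs from compound 3 by methyl in place of hydrogen on a saturated chain carbon bound to an oxygen next to a carbonyl group, the same change as from compound 2 to compound 1. The difference between the two cores is not broken down here. Since the measured step was an at least 6.3-fold higher number from compound 2 to compound 1 (0.80 log units; beyond the scatter), a step of similar size is expected here, so a 4.4-fold higher number from compound 3 to compound 4 (0.65 log units; beyond the scatter) is estimated, giving compound 4 an expected 150000 nM in this assay, likely reported only as a limit.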

Compound 4, half-maximal cytotoxic concentration: 13200 nM
Compound 4: middle estimate off by 11-fold (1.06 log units), on the high side, outside the stated range (below it).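

In this assay, replacing methoxycarbonyl with ethoxycarbonyl gives a 2.6-fold lower number from compound 3 to compound 4 (0.41 log units; beyond the scatter). Set beside the earlier step, the same change goes the opposite way on the other core, so its effect did not carry over from one core to the other: the same change on two cores in this assay, an at least 6.3-fold higher number (0.80 log units; beyond the scatter) from compound 2 to compound 1 and a 2.6-fold lower number (0.41 log units; beyond the scatter) from compound 3 to compound 4, at least 16-fold (1.21 log units) apart, beyond the scatter of two such steps For compound 1, > 100000 nM is a limit of the assay and not a number, and these two pairs do not show which feature of the cores decides the direction of the change.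

The compounds shown leave open how a longer chain, such as propoxycarbonyl, or a carboxylic acid in the same place would behave on either core. They also leave open which way the change would go on a further core.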